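The compounds below may be only part of what the source reports. "The series", "measured", "known", "first", "only" and "open" are said of these compounds alone.

In a functional assay on A549 cells (Homo sapiens) for cytotoxicity, read by MTT assay (on this read-out higher numbers stand for weaker inhibition and lower numbers for stronger inhibition), three compounds of a shared core have been examined. Compound 1, `COc1c(C)c(OC)c2c(c1C=O)O[C@H](c1ccccc1)C[C@H]2O`, gives 137000 nM. Compound 2, `COc1cc(O)c(C=O)c2c1[C@H](OC)C[C@@H](c1ccccc1)O2`, gives "not active" (no number reported). Compound 3, `COc1c(C)c(O)c(C=O)c2c1[C@H](O)C[C@@H](c1ccccc1)O2`, gives "not active" (no number reported) in this assay. Compound 3 therefore stands without a single number, and it is joined in that position by compound 2, so that only compound 1 carries a value on the scale.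

Compound 4, `COc1c(C)c(O)c(C=O)c2c1[C@H](OC)C[C@@H](c1ccccc1)O2`, has not yet been measured. It differs from compound 3 by methyl in place of hydrogen on an oxygen on a saturated carbon, a change that, read one bond further out, turns a hydroxy into a methoxy. Within the data shown here, no measured pair shows the size of such a step here, so no direction can be drawn from the data; with compound 2, which also carries a methoxy at that oxygen, giving no number, no gain beyond the scatter is anticipated. Compound 4 is expected to give about 150000 nM in this assay, within a range of 50000 nM to 500000 nM, with a strong chance that no number is reported at all.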

Compound 4, half-maximal inhibitory concentration: 104000 nM
Compound 4: the middle estimate sits 1.4-fold (0.16 log units) above what was measured; low and high end bracket the measured number.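

In this assay, among these compounds, compound 4 gives 104000 nM while compound 3 carries no number, so no step between compound 3 and compound 4 can be read. Nothing at hand bears on this result. The compounds shown leave open what hydroxy to methoxy does to the read-out on this core.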